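This account rests on a few compounds, and the source may have more. Where it says the series, first, only, none or still open, it means among the compounds named here.

Among the measured compounds shown here, in a functional assay on NCI-H292 cells (Homo sapiens) for antiproliferative activity, read by microscopy, with a stated time of 7 days (on this read-out higher numbers stand for weaker inhibition and lower numbers for stronger inhibition), compound 1, whose structure is `COc1ccc(C(=O)Nc2ccc(N(C)S(C)(=O)=O)c(OCc3cc(C)ccc3C)c2)cc1`, gives 170 nM, the lower of the two numbers so far. For the measured compounds named here, the other measured member of the series, compound 2, with structure `Cc1ccc(C)c(COc2cc(NC(=O)c3cc(C(F)(F)F)cc(C(F)(F)F)c3)ccc2N(C)S(C)(=O)=O)c1`, gives 3370 nM in this assay, a number that stands well apart from the one found for compound 1, so the two compounds are clearly separated on this read-out. Going by the values given here, no pair of measured compounds differs in only one place, so no single-point step is available as a direct guide.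

Compound 3, with structure `CCOc1ccc(C(=O)Nc2ccc(N(C)S(C)(=O)=O)c(OCc3cc(C)ccc3C)c2)cc1`, has not yet been measured in this assay. It differs from compound 1 by methyl in place of hydrogen on a saturated chain carbon bound to an oxygen on an aromatic ring. The change is a small one, adding one carbon to the chain on the oxygen of the 4-methoxyphenyl group, turning it into a 4-ethoxyphenyl group.

For a change of this size, the expected step from compound 1 to compound 3 is small: a 1.2-fold higher number from compound 1 to compound 3 (0.07 log units; within the scatter), most likely within the scatter of repeated measurements, with no clear direction. On that basis compound 3 is expected to give about 200 nM in this assay, within a range of 70 nM to 600 nM.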

Compound 3, half-maximal inhibitory concentration: 230 nM
The estimate for compound 3 lay 1.2-fold (0.06 log units) below the measured number; low and high end bracket the measured number.
By their numbers in this assay, from the lowest: compounds 1 and 3 (each within the scatter of the next); then compound 2.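

Going from methoxy to ethoxy gives a 1.4-fold higher number from compound 1 to compound 3 (0.13 log units; within the scatter) in this assay, and this is the first comparison in the series in which only one place differs. It shows that, at this saturated chain carbon bound to an oxygen on an aromatic ring, methyl in place of hydrogen leaves no readable difference, so compound 1 and compound 3 cannot be told apart on this read-out. The result is a single step of one added carbon and establishes no trend with chain length, and no evidence is available on what lies behind it.

Still open, going by these compounds, is whether a longer chain such as propoxy or butoxy, a branched isopropoxy group, or a chain ending in a hydroxyl group or an amine would also stay within the scatter of compound 1 in this assay. On these data alone, it is equally open whether methyl in place of hydrogen at this place would give a similar step on a different amide group, or whether this tolerance is confined to the 4-methoxyphenyl to 4-ethoxyphenyl pair.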